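Working notes: pyridin-2-yl in place of phenyl

The source may report more compounds than this note shows. Statements on the series, on what has been measured and on what is new or still open speak of the compounds shown alone.

In an ADME assay on J774.A1 cells (Mus musculus) for cytotoxicity (on this read-out higher numbers stand for lower toxicity in this test and lower numbers for higher toxicity in this test), compound 1 `c1ccc(N2CCN(c3nc(-n4ccc5ccccc54)c4ccccc4n3)CC2)cc1` gives 5.67 ug/mL, the higher of the two measured values, and compound 2 `CN1CCN(c2nc(-c3cn(C)c4ccccc34)c3ccccc3n2)CC1` gives 1.03 ug/mL, a gap beyond the scatter. Compound 3 `c1ccc(N2CCN(c3nc(-n4ccc5ccccc54)c4ccccc4n3)CC2)nc1` has pyridin-2-yl in place of phenyl on an amine nitrogen in a ring. For the measured compounds named here, compounds 1 and 2 differ in more than one place, and no measured step covers this change. The expected step is small and within the scatter, slightly downward: a 1.3-fold lower number from compound 1 to compound 3 (0.10 log units; within the scatter). Compound 3 is estimated at 4.5 ug/mL, with an expected range of 1.8 ug/mL to 11 ug/mL.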

Compound 3, half-maximal cytotoxic concentration: 1.35 ug/mL
Compound 3: the middle estimate sits 3.3-fold (0.52 log units) above what was measured; the measured number lies below the stated range.
By their numbers in this assay, from the lowest: compounds 2 and 3 (each within the scatter of the next); then compound 1.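

On the amine nitrogen in a ring, pyridin-2-yl in place of phenyl is not a neutral exchange in this assay: the change gives a 4.2-fold lower number from compound 1 to compound 3 (0.62 log units; beyond the scatter) and moves this core toward higher toxicity in this test. This position therefore responds to one aromatic ring nitrogen, with the heavy-atom count unchanged. No available evidence bears on the reason for this step.

Still open, going by these compounds, is whether the step depends on where the ring nitrogen sits, as pyridin-3-yl or pyridin-4-yl would show. Also open, on these data alone, is how a pyrimidin-2-yl group would read at this position.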